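Morpholine for diisopropylamine on the dithiocarbamate

A few compounds are considered here, and "the series" means these few. Any claim that something is new, unique, unknown or untested is made for them only; others in the source may bear on it.

Notes on three measured dithiocarbamates and one yet to be measured. Compound 1 `COc1ccc2occ(CSC(=S)N(C(C)C)C(C)C)c(=O)c2c1` gives 8900 nM in a functional assay on HEp-2 cells (Homo sapiens) for antiproliferative activity, read by MTT assay, with a stated time of 72 h; a higher number here means a weaker inhibitor, a lower number a stronger inhibitor; compound 3 `COc1ccc2occ(CSC(=S)N3CCOCC3)c(=O)c2c1` gives 4800 nM in this assay, the step being a 1.9-fold lower number from compound 1 to compound 3 (0.27 log units; within the scatter). Compound 2 `CC(C)N(C(=S)SCc1oc2ccccc2c(=O)c1Cl)C(C)C` gives 20000 nM in this assay, the highest of the three numbers; its gap to compound 1 is the nearest and its gap to compound 3 the widest, both beyond the scatter. Compound 4 `O=c1c(Cl)c(CSC(=S)N2CCOCC2)oc2ccccc12` differs from compound 2 by morpholin-4-yl in place of diisopropylamino on a thiocarbonyl carbon. Among the measured compounds shown here, the only measured step that bears on this change is the one from compound 1 to compound 3, the same exchange on the same thiocarbonyl carbon, which gave a 1.9-fold lower number from compound 1 to compound 3 (0.27 log units; within the scatter) and stayed within the scatter. On that single precedent the expected step for compound 4 in this assay is small and, if anything, towards a lower number, a 1.8-fold lower number from compound 2 to compound 4 (0.26 log units; within the scatter). For compound 4 the estimate in this assay is 11000 nM, with a range from 5000 nM to 25000 nM.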

Compound 4, half-maximal inhibitory concentration: 9000 nM
Estimate against measurement, compound 4: 1.2-fold (0.09 log units) above, within the range that was stated.
By their numbers in this assay, from the lowest: compounds 3, 1 and 4 (each within the scatter of the next); then compound 2.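

In this assay the exchange of diisopropylamino for morpholin-4-yl on a thiocarbonyl carbon now has a second reading on a different core, and here the step (a 2.2-fold lower number from compound 2 to compound 4 (0.35 log units; beyond the scatter)) lies beyond the scatter, which the earlier step alone did not. The two readings agree in size: the same change on two cores in this assay, a 1.9-fold lower number (0.27 log units; within the scatter) from compound 1 to compound 3 and a 2.2-fold lower number (0.35 log units; beyond the scatter) from compound 2 to compound 4, 1.2-fold (0.08 log units) apart, within the scatter of two such steps. Taken together they describe a modest change on both cores shown, and no pair here goes against that.

The compounds shown do not separate the ring from its oxygen as the source of the step, and piperidin-1-yl on the same thiocarbonyl carbon would bear on that. As far as these compounds go, how an open-chain dimethylamino group would compare with diisopropylamino on either core also remains open.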